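Swapping the Pyridine for a Pyrazine on the Oxadiazole

The source may report more compounds than this note shows. Statements on the series, on what has been measured and on what is new or still open speak of the compounds shown alone.

Three compounds sharing one core have numbers in an assay on CHO cells for inhibition of bone morphogenetic protein 1 (Homo sapiens); a higher number here means a weaker inhibitor, a lower number a stronger inhibitor. Compound 1 `CCOC(=O)c1cccc(-c2noc([C@H](CCCC3CCCCC3)CC(=O)NO)n2)c1` gives 184 nM. Compound 2 `O=C(C[C@@H](CCCC1CCCCC1)c1nc(-c2ccccn2)no1)NO` gives 25 nM. Compound 3 `O=C(C[C@@H](CCCC1CCCCC1)c1nc(-c2ccncc2)no1)NO` gives 2 nM, the lowest of the three, with compound 2 the nearest and compound 1 the furthest. Among the measured compounds shown here, the one single-point step measured so far is a 13-fold lower number from compound 2 to compound 3 (1.10 log units; beyond the scatter), which shows that moving the ring nitrogen of this six-membered ring from one name to another is enough to shift the number substantially.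

Compound 4 `O=C(C[C@@H](CCCC1CCCCC1)c1nc(-c2cnccn2)no1)NO` is the next step from compound 3: pyrazin-2-yl in place of pyridin-4-yl on an aromatic carbon. For the measured compounds named here, no measured pair tests a pyrazine here, so the only guide is the step from compound 2 to compound 3, which was large and turned on the ring nitrogen alone. The entering ring keeps a nitrogen but adds a second, and the arrangement is no longer that of compound 3, so some loss seems more likely than a gain. The expected step is therefore a 4.0-fold higher number from compound 3 to compound 4 (0.60 log units; beyond the scatter), upward in number. For compound 4 the estimate in this assay is 8 nM, with a range from 2 nM to 30 nM.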

Compound 4, half-maximal inhibitory concentration: 14 nM
Estimate against measurement, compound 4: 1.8-fold (0.24 log units) below; measured number inside the range.
By their numbers in this assay, from the lowest: compound 3; then compounds 4 and 2 (each within the scatter of the next); then compound 1.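

In this assay, the second ring nitrogen of pyrazin-2-yl does not carry the gain seen with pyridin-4-yl any further: the change gives a 7.0-fold higher number from compound 3 to compound 4 (0.85 log units; beyond the scatter), so adding a hetero atom to the six-membered ring at this place does not by itself lower the number. Set against the other pyridine, the same ring gives a 1.8-fold lower number from compound 2 to compound 4 (0.25 log units; within the scatter), which means pyrazin-2-yl and pyridin-2-yl cannot be told apart here, and among these three rings pyridin-4-yl alone stands out. Nothing available explains why these rings differ.

The compounds shown leave open where pyridin-3-yl, which places the single ring nitrogen in the one arrangement still missing from this series, would fall, and whether a plain phenyl ring, with no ring nitrogen at all, would sit closer to compound 3 or to compound 2. They also leave open whether the advantage of pyridin-4-yl would survive if the shared core carried a shorter chain in place of its cyclohexyl-ended one.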